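Heteroaryl swap on the core of compound 1

The source may report more compounds than this note shows. Statements on the series, on what has been measured and on what is new or still open speak of the compounds shown alone.

Compound 1 `FC(F)(F)c1ccccc1OC1CCN(c2ccc(-n3ccnc3)nn2)CC1` sits lowest of the three numbers in an assay on microsomes from liver for inhibition of acyl-CoA desaturase 1 (Rattus norvegicus); on this read-out higher numbers stand for weaker inhibition and lower numbers for stronger inhibition: compound 1 gives 4 nM, compound 2 `CC(=O)c1ccccc1OC1CCN(c2ccc(-n3ccnc3)nn2)CC1` gives 34 nM, and compound 3 `COc1ccccc1OC1CCN(c2ccc(-n3ccnc3)nn2)CC1` gives 543 nM. Every measured step concerns the group on the other aromatic carbon: an 8.5-fold higher number from compound 1 to compound 2 (0.93 log units; beyond the scatter), a 140-fold higher number from compound 1 to compound 3 (2.13 log units; beyond the scatter), and a 16-fold higher number from compound 2 to compound 3 (1.20 log units; beyond the scatter). Compound 4 `FC(F)(F)c1ccccc1OC1CCN(c2ccc(-c3nnco3)nn2)CC1` changes a different part: 1,3,4-oxadiazol-2-yl in place of 1H-imidazol-1-yl on an aromatic carbon. For the measured compounds named here, no measured step touches this ring, so the measured steps give no direct read on its size. Because compound 1 at 4 nM keeps its trifluoromethyl in compound 4, only a modest shift toward a higher number is expected. A step of about a 2.5-fold higher number from compound 1 to compound 4 (0.40 log units; beyond the scatter) is expected. Compound 4 is estimated at 10 nM, within 2 nM to 60 nM.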

Compound 4, half-maximal inhibitory concentration: 22 nM
For compound 4 the middle estimate is 2.2-fold (0.34 log units) below the measured one, within the range that was stated.
By their numbers in this assay, from the lowest: compound 1; then compounds 4 and 2 (each within the scatter of the next); then compound 3.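

In this assay, the ring on the core's other end also moves the number: 1,3,4-oxadiazol-2-yl in place of 1H-imidazol-1-yl gives a 5.5-fold higher number from compound 1 to compound 4 (0.74 log units; beyond the scatter). For the compounds shown here, the earlier steps covered only the group on the other aromatic ring, so this is the first sign that this position matters too, though trifluoromethyl alone does not fix the number. Nothing available explains this step.

Going by these compounds, whether the step is the same size with acetyl or methoxy in place of trifluoromethyl remains open. So does the effect of a pyridin-2-yl ring or an open-chain amide at this position.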